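Side-chain ether to carbon chain: working notes on compound 3

This account rests on a few compounds, and the source may have more. Where it says the series, first, only, none or still open, it means among the compounds named here.

compound 1 `C=C(N=[N+]=[N-])c1cn(COCCO)c(=O)[nH]c1=O` — > 100 ug/mL
compound 2 `C=C(N=[N+]=[N-])c1cn(COC(CO)CO)c(=O)[nH]c1=O` — > 100 ug/mL

In a functional assay on HFF cells (Homo sapiens) (a higher number here means a weaker inhibitor, a lower number a stronger inhibitor), compound 1 gives only a limit, > 100 ug/mL. In this assay compound 2 likewise gives only a limit, > 100 ug/mL. The step that the two limits leave unreadable from compound 1 to compound 2 is therefore not readable, and compound 2 stands at the limit of > 100 ug/mL in this assay, at which 2 of the 2 values shown sit. Compound 3 `C=C(N=[N+]=[N-])c1cn(CCC(CO)CO)c(=O)[nH]c1=O` differs by 3-hydroxy-2-(hydroxymethyl)propyl in place of 2-hydroxy-1-(hydroxymethyl)ethoxy on a saturated chain carbon bound to an aromatic nitrogen. For the measured compounds named here, no measured step bears on this change; the only evidence is the limit of > 100 ug/mL in this assay, at which 2 of the 2 values shown sit. For compound 3 the expectation is 150 ug/mL (range 50 ug/mL to 500 ug/mL), most likely again only a limit. The step that the limit leaves unreadable from compound 2 to compound 3 is thus expected to be none beyond the scatter.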

Compound 3, half-maximal inhibitory concentration: > 100 ug/mL
Compound 3 gave a limit, no number (the forecaster's own chance of this, stated with the estimate: 85%); the middle value does not contradict the limit.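

In this assay, for the compounds shown here, compound 3 gives only a limit, > 100 ug/mL, and no step among compound 1, compound 2 and compound 3 can be read. The compounds shown leave open whether these side chains differ at all in this assay.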